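The source may hold more compounds than are shown below. What is called first, only, known or untested is meant among the compounds shown, and "the series" means these compounds.

Three measured compounds share one core and differ only in how one stereocentre at a saturated ring carbon is drawn. Compound 1 `Fc1cccc(-c2cn([C@@H]3CN4CCC3CC4)nn2)c1` gives 2.25 nM in an assay on HEK293 cells for displacement of a labelled ligand from Neuronal acetylcholine receptor; alpha3/beta4 (Homo sapiens), read by scintillation counting, with a stated time of 120 min; a lower number here means a stronger inhibitor, a higher number a weaker inhibitor. Compound 2 `Fc1cccc(-c2cn(C3CN4CCC3CC4)nn2)c1` gives 5.24 nM in this assay, the second highest of the three numbers; the change from compound 1 to compound 2 is a 2.3-fold higher number from compound 1 to compound 2 (0.37 log units; beyond the scatter), and the change from compound 2 to compound 3 `Fc1cccc(-c2cn([C@H]3CN4CCC3CC4)nn2)c1`, which gives 362 nM in this assay, is a 69-fold higher number from compound 2 to compound 3 (1.84 log units; beyond the scatter). Compound 4 `FCCOc1cccc(-c2cn(C3CN4CCC3CC4)nn2)c1` differs from compound 2 by 2-fluoroethoxy in place of fluoro on an aromatic carbon. Among the measured compounds shown here, none of the measured steps bears on this change; each concerns only the drawn configuration, not the groups on the aromatic ring. For the measured compounds named here, with no comparable step to go by, compound 4 is expected to give 6 nM, between 2 nM and 20 nM, an expected step of a 1.1-fold higher number from compound 2 to compound 4 (0.06 log units; within the scatter).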

Compound 4, inhibition constant: 20.9 nM
The estimate for compound 4 lay 3.5-fold (0.54 log units) below the measured number; measured number outside the range, above it.
By their numbers in this assay, from the lowest: compound 1; then compound 2; then compound 4; then compound 3.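

Among the compounds shown here, this is the first view of the aromatic carbon that carries the fluoro group, as the earlier steps changed only the drawn configuration. In this assay, the move to the larger 2-fluoroethoxy group gives a 4.0-fold higher number from compound 2 to compound 4 (0.60 log units; beyond the scatter) and so costs something, yet the compound stays far closer to compound 2 than the drawn configuration alone can move it (a 69-fold higher number from compound 2 to compound 3 (1.84 log units; beyond the scatter)). Nothing available here explains the rise at this position.

As far as these compounds go, whether a shorter methoxy, a longer chain or an amine at this place would fare better remains open. So does how the two drawn configurations of compound 4 would compare.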